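Carbamate in place of ether on the ring oxygen

The source may report more compounds than this note shows. Statements on the series, on what has been measured and on what is new or still open speak of the compounds shown alone.

Measured so far:
compound 1 `COc1cccc(NC(=O)Oc2cc(=O)n(CCCO)c3c2CC(CC=C(C)C)C(C)(C)C3)c1`: 0%
compound 2 `CC(C)=CCC/C(C)=C/CC1Cc2c(OCC=C(C)C)cc(=O)n(CCCO)c2CC1(C)C`: 15.9%
compound 3 `COc1ccc(OCCCOc2cc(=O)n(CCCO)c3c2CC(C/C=C(\C)CCC=C(C)C)C(C)(C)C3)cc1`: 0%

In a functional assay on PANC-1 cells (Homo sapiens) for inhibition, read by MTT assay, with a stated time of 24 h, tested at 10 uM (on this read-out higher numbers stand for more inhibition at the one concentration tested (going by the name of the read-out) and lower numbers for less inhibition), compound 3 gives 0%, level with compound 1 and together the lowest of the three numbers. Within the data shown here, the only measured step is a number 15.9 percentage points lower from compound 2 to compound 3 (beyond the scatter), a change on the oxygen on an aromatic ring, and it is the only step that bears on the present one.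

Compound 4 `COc1cccc(NC(=O)Oc2cc(=O)n(CCCO)c3c2CC(C/C=C(\C)CCC=C(C)C)C(C)(C)C3)c1` carries (3-methoxyphenyl)carbamoyl in place of 3-(4-methoxyphenoxy)propyl on an oxygen on an aromatic ring. Compound 1 bears the same (3-methoxyphenyl)carbamoyl on that oxygen and gives 0% in this assay. With the carbamate already at the bottom in compound 1, no step beyond the scatter is expected, a number 3 percentage points higher from compound 3 to compound 4 (within the scatter) being the estimated step. The estimate for compound 4 is 3%, range 0% to 14%.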

Compound 4, a percentage reported as inhibition, at one concentration (the size of the read-out at that concentration, not a potency): 11.3%
Beside the measured number, compound 4's estimate is 8.3 percentage points below it, and the stated range covers the measured number.
By their numbers in this assay, from the lowest: compounds 1 and 3 (each within the scatter of the next); then compounds 4 and 2 (each within the scatter of the next).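

In this assay, a step of a number 11.3 percentage points higher from compound 3 to compound 4 (beyond the scatter) shows that this oxygen on an aromatic ring responds to (3-methoxyphenyl)carbamoyl in place of 3-(4-methoxyphenoxy)propyl. The carbamate's number also depends on the chain elsewhere on the shared core: a step of a number 11.3 percentage points higher from compound 1 to compound 4 (beyond the scatter) comes with 3-methylbut-2-en-1-yl in place of hydrogen on a saturated chain carbon bound to a double-bonded chain carbon, while a number 4.6 percentage points lower from compound 2 to compound 4 (within the scatter) separates the carbamate from 3-methylbut-2-en-1-yl on the oxygen. No evidence available here accounts for these steps.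

As far as these compounds go, whether an amine or a carboxylic acid on that oxygen would change the number remains open.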